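This account rests on a few compounds, and the source may have more. Where it says the series, first, only, none or still open, it means among the compounds named here.

Compound 3 `CCN(CC)CCCNc1ccc(S(=O)(=O)NC(=O)c2ccc(N3CCN(CC4=C(c5ccc(C(F)(F)F)cc5)CC(C)(C)CC4)CC3)cc2Oc2cnc3[nH]ccc3c2)cc1[N+](=O)[O-]` gives 0.3 nM in an assay on isolated protein for displacement of a labelled ligand from Apoptosis regulator Bcl-2 (Homo sapiens), with a stated time of 15 min (on this read-out lower numbers stand for stronger inhibition and higher numbers for weaker inhibition), which is the lowest number among the three measured compounds. Compound 1 `CC1(C)CCC(CN2CCN(c3ccc(C(=O)NS(=O)(=O)c4ccc(NCC5CCOCC5)c([N+](=O)[O-])c4)c(Oc4cnc5[nH]ccc5c4)c3)CC2)=C(c2ccc(C(F)(F)F)cc2)C1` gives 1.5 nM, and compound 2 `CC1(C)CCC(CN2CCN(c3ccc(C(=O)NS(=O)(=O)c4ccc(NCC5CCOCC5)c([N+](=O)[O-])c4)c(Oc4cnc5[nH]ccc5c4)c3)CC2)=C(c2ccc(C(F)(F)F)c(Cl)c2)C1` gives 0.8 nM; the gap from compound 2 to compound 3 lies beyond the scatter, as does the gap from compound 1 to compound 3, so compound 3 is the strongest inhibitor here. Compound 4 `CC(C)C(=O)N1CCC(CNc2ccc(S(=O)(=O)NC(=O)c3ccc(N4CCN(CC5=C(c6ccc(C(F)(F)F)cc6)CC(C)(C)CC5)CC4)cc3Oc3cnc4[nH]ccc4c3)cc2[N+](=O)[O-])CC1` differs from compound 3 in one place: 1-(isopropylcarbonyl)piperidin-4-yl in place of 2-(diethylamino)ethyl on a saturated chain carbon bound to a nitrogen on an aromatic ring.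

Of the measured steps, the one that bears on this change is a 5.0-fold lower number from compound 1 to compound 3 (0.70 log units; beyond the scatter), where an oxan-4-yl ring gave way to the 2-(diethylamino)ethyl chain and the number fell. The other step, a 1.9-fold lower number from compound 1 to compound 2 (0.27 log units; within the scatter), concerns a different part of the shared core and stays within the scatter. Compound 4 now removes that same chain and puts a six-membered non-aromatic ring in its place, which resembles the situation of compound 1 more than that of compound 3. Going by the values given here, the number for compound 4 is therefore expected to rise, with a step of about a 3.3-fold higher number from compound 3 to compound 4 (0.52 log units; beyond the scatter), because a 5.0-fold lower number from compound 1 to compound 3 (0.70 log units; beyond the scatter) is the only guide and its reverse is the likeliest outcome. Compound 4 is estimated at 1 nM, with a range from 0.3 nM to 3 nM.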

Compound 4, half-maximal inhibitory concentration: 2.4 nM
The estimate for compound 4 lay 2.4-fold (0.38 log units) below the measured number, within the range that was stated.
By their numbers in this assay, from the lowest: compound 3; then compounds 2, 1 and 4 (each within the scatter of the next, the first and the last beyond it).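

In this assay, the step of an 8.0-fold higher number from compound 3 to compound 4 (0.90 log units; beyond the scatter) shows that replacing 2-(diethylamino)ethyl with 1-(isopropylcarbonyl)piperidin-4-yl on this saturated chain carbon gives up the whole advantage seen in a 5.0-fold lower number from compound 1 to compound 3 (0.70 log units; beyond the scatter), and more in numerical terms. The step of a 1.6-fold higher number from compound 1 to compound 4 (0.20 log units; within the scatter) stays within the scatter, so the two groups with a six-membered non-aromatic ring, oxan-4-yl and 1-(isopropylcarbonyl)piperidin-4-yl, cannot be told apart here, even though the second is larger and carries a carbonyl, and among these compounds only the open 2-(diethylamino)ethyl chain stands apart from them. Nothing measured here explains why this chain differs from the two ring-bearing groups.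

The compounds shown cannot separate the contribution of the amine nitrogen in the chain from that of the open, ring-free shape, a question that a plain pentyl chain or a piperidin-4-yl ring with a free amine could address. Going by these compounds, it also remains open whether the 3-(diethylamino)propyl side chain and the chloro group of compound 2 would add together on the shared core.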